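This account rests on a few compounds, and the source may have more. Where it says the series, first, only, none or still open, it means among the compounds named here.

In a functional assay on the whole organism with Mus musculus as the target (on this read-out higher numbers stand for an effect only at larger amounts of compound and lower numbers for an effect already at smaller amounts), compound 1 `CCC(O)CNC(=O)/C=C/c1cccc(C(F)(F)F)c1` gives 90 mg/kg. Compound 2 `O=C1CCC(O)(c2cccc(C(F)(F)F)c2)N1` gives > 200 mg/kg, which is a limit of the assay and not a number. Compound 2 therefore stands at the limit of > 200 mg/kg in this assay, at which 1 of the 2 values shown sits.

Compound 3 `CCCN1C(=O)CCC1(O)c1cccc(C(F)(F)F)c1` differs from compound 2 in one place: propyl in place of hydrogen on an amide-type nitrogen in a ring. Among the measured compounds shown here, no measured pair shows this change, so the size of the step in this assay cannot be read from the data. For the measured compounds named here, compound 1, at 90 mg/kg, shows only that a number can be reached. A modest shift towards effect at smaller amounts is expected, and a second limit reading remains possible. The expected step of an at least 1.5-fold lower number from compound 2 to compound 3 (0.18 log units; that floor lies within the scatter) is an estimate only. For compound 3 the expected value is 130 mg/kg, with an estimated range of 60 mg/kg to 280 mg/kg.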

Compound 3, dose for half-maximal effect: > 200 mg/kg
Compound 3 ended at the assay's limit; the forecaster's own chance of this, stated with the estimate: 35%; middle value at least 1.5-fold (0.18 log units) away from the limit.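

In this assay compound 2 and compound 3 both end at a limit of the assay and not a number, so no step can be read between them: the limit of > 200 mg/kg in this assay, at which 2 of the 3 values shown sit.

The compounds shown leave open whether propyl in place of hydrogen on the amide-type nitrogen changes the dose for half-maximal effect at all.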